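This account rests on a few compounds, and the source may have more. Where it says the series, first, only, none or still open, it means among the compounds named here.

Compound 1 `CCCSc1nc(N/N=C(\C)c2ccccc2O)c2nnn(Cc3ccccc3)c2n1`: 11000 nM
Compound 2 `CCCSc1nc(N/N=C/c2ccccc2)c2nnn(Cc3ccccc3)c2n1`: > 64000 nM
Compound 3 `CCCSc1nc(N/N=C/c2ccccc2F)c2nnn(Cc3ccccc3)c2n1`: not yet measured

These values come from a functional assay on MCF7 cells (Homo sapiens) for antiproliferative activity, read by MTT assay, with a stated time of 72 h; a lower number here means a stronger inhibitor, a higher number a weaker inhibitor. In this assay compound 2 gives > 64000 nM, which is a limit of the assay and not a number, and so compound 2 stands at the limit of > 64000 nM in this assay, at which 1 of the 2 values shown sits.

Compound 3 differs from compound 2 in one place, fluoro in place of hydrogen on an aromatic carbon, ortho to a large group, turning phenyl into 2-fluorophenyl.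

Among the compounds with values here, only one measured step bears on this change. It is an at least 5.8-fold higher number from compound 1 to compound 2 (0.76 log units; beyond the scatter), and it alters the same side group as the change to compound 3, though through a different exchange. That step has a limit at one end, so its true size is not known. Within the data shown here, no measured compound carries fluoro, and the data give no direct guide to its effect. A change of this small size is therefore expected to leave compound 3 weak, with no step beyond the scatter. The expected change for compound 3 is an at least 1.0-fold lower number from compound 2 to compound 3 (0.02 log units; that floor lies within the scatter). Compound 3 is estimated at 60000 nM, with an expected range of 25000 nM to 120000 nM.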

Compound 3, half-maximal inhibitory concentration: > 64000 nM
Compound 3 ended at the assay's limit; the forecaster's own chance of this, stated with the estimate: 65%; middle value at least 1.0-fold (0.02 log units) away from the limit.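

In this assay compound 3 gives > 64000 nM, which is a limit of the assay and not a number. Fluoro in place of hydrogen on an aromatic carbon, turning phenyl into 2-fluorophenyl, leaves the compound without a measured value, and the step between the two compounds that differ by this change cannot be read, since both of its ends are limits: the limit of > 64000 nM in this assay, at which 2 of the 3 values shown sit. The one readable comparison is an at least 5.8-fold higher number from compound 1 to compound 3 (0.76 log units; beyond the scatter), so the side group holding oxygen and an extra carbon now stands apart from two side groups that both end at the limit, one with fluoro and one without.

The compounds shown leave open whether the oxygen, the extra carbon or the two together separate compound 1 from compound 3, since that exchange alters more than one atom of the side group. They also leave open whether a hydroxyl group alone on the 2-fluorophenyl position's carbon, a methoxy group or an amine at this place would bring a value within reach of this assay, and what a longer chain on the sulfur would do.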